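A few compounds are considered here, and "the series" means these few. Any claim that something is new, unique, unknown or untested is made for them only; others in the source may bear on it.

In a functional assay on HL-60 cells (Homo sapiens) for cytotoxicity, read by MTT assay, with a stated time of 24 h (on this read-out lower numbers stand for stronger inhibition and higher numbers for weaker inhibition), compound 1 `Nc1nn(Cc2cn(CCC(F)(F)C(F)(F)C(F)(F)C(F)(F)C(F)(F)C(F)(F)F)nn2)c2nc(-c3ccccc3)cc(C(F)(F)F)c12` gives 97.6 ug/mL and compound 2 `Nc1nn(Cc2cn(CC(=O)Nc3ccccc3)nn2)c2nc(-c3ccccc3)cc(C(F)(F)F)c12` gives 96.3 ug/mL, two values within the usual scatter of each other. Compound 3 `Nc1nn(Cc2cn(CC(=O)Nc3ccc(F)cc3)nn2)c2nc(-c3ccccc3)cc(C(F)(F)F)c12` gives 44.8 ug/mL, the lowest number of the three and beyond the scatter from both others. Compound 4 `Nc1nn(Cc2cn(CC(=O)NC3CCCCC3)nn2)c2nc(-c3ccccc3)cc(C(F)(F)F)c12`, not yet measured, has cyclohexyl in place of 4-fluorophenyl on an amide-type nitrogen. Going by the values given here, the one measured step that bears on this is a 2.1-fold lower number from compound 2 to compound 3 (0.33 log units; beyond the scatter), a modest one, with fluoro in place of hydrogen on an aromatic carbon. Among the compounds with values here, compound 4 has no such fluoro, though no measured step covers this exchange of rings. A modest rise is therefore expected, a 2.1-fold higher number from compound 3 to compound 4 (0.33 log units; beyond the scatter), in this assay. For compound 4 the estimated value is 95 ug/mL, with an expected range from 40 ug/mL to 200 ug/mL.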

Compound 4, half-maximal inhibitory concentration: 43 ug/mL
Compound 4: the middle estimate sits 2.2-fold (0.34 log units) above what was measured; the range from low to high includes it.
By their numbers in this assay, from the lowest: compounds 4 and 3 (each within the scatter of the next); then compounds 2 and 1 (each within the scatter of the next).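

Cyclohexyl in place of 4-fluorophenyl on the amide-type nitrogen gives a 1.0-fold lower number from compound 3 to compound 4 (0.02 log units; within the scatter) in this assay, so at this position neither the fluoro group nor an aromatic ring is needed to hold this level. Cyclohexyl in place of phenyl gives a 2.2-fold lower number from compound 2 to compound 4 (0.35 log units; beyond the scatter), which shows that a second, non-aromatic ring can also lead to a lower number than phenyl. No measurement here explains why these rings compare as they do. Going by these compounds, it remains open whether cyclopentyl, a straight hexyl chain or a 4-aminocyclohexyl group on the same nitrogen would hold this level.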